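A few compounds are considered here, and "the series" means these few. Any claim that something is new, unique, unknown or untested is made for them only; others in the source may bear on it.

Compound 1 `O=C1C2=C(CCCC2)C(=O)N1c1ccc(Cl)cc1F` gives 240 nM in a functional assay on the whole organism with Scenedesmus acutus as the target, with a stated time of 20 h; a higher number here means a weaker inhibitor, a lower number a stronger inhibitor.
Compound 2 `COC(=O)c1cc(N2C(=O)C3=C(CCCC3)C2=O)ccc1Cl` gives 1620 nM in this assay.
Compound 3 `CC(C)COC(=O)c1cc(N2C(=O)C3=C(CCCC3)C2=O)c(F)cc1Cl` gives 407 nM in this assay.

Among these three, compound 2 gives the highest number, with a gap beyond the usual scatter to both compound 3 and compound 1; it is the weakest inhibitor shown. Compound 4 `CCCCCCCCOC(=O)c1cc(N2C(=O)C3=C(CCCC3)C2=O)ccc1Cl` differs from compound 2 in one place: heptyl in place of hydrogen on a saturated chain carbon bound to an oxygen next to a carbonyl group. For the measured compounds named here, only one measured step exists, a 1.7-fold higher number from compound 1 to compound 3 (0.23 log units; within the scatter), and it concerns a different spot, adding an ester onto the ring rather than extending one, so it offers no direct guide. Compound 3 carries a longer ester than compound 2 but also a fluorine, and gives the lower of the two numbers; with two changes at once this is only a hint. The expected step is therefore modest and downward, a 2.0-fold lower number from compound 2 to compound 4 (0.31 log units; beyond the scatter), with wide uncertainty. Compound 4 is estimated at 800 nM, between 250 nM and 2500 nM.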

Compound 4, half-maximal inhibitory concentration: > 100000 nM
Compound 4: a limit, no number; the forecaster's own chance of this, stated with the estimate: 5%; middle value at least 120-fold (2.09 log units) away from the limit.
By their numbers in this assay, from the lowest: compounds 1 and 3 (each within the scatter of the next); then compound 2. At a limit, above all of these: compound 4.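

For the compounds shown here, until now, no step showed what the length of the ester chain does on its own. Going from methyl to octyl on this ester oxygen gives an at least 61-fold higher number from compound 2 to compound 4 (1.79 log units; beyond the scatter) in this assay, so this single change at this place is enough to take inhibition out of the measurable range. Compound 4 gives no number here, only a limit: the limit of > 100000 nM in this assay, at which 1 of the 4 values shown sits.

The compounds shown leave open how the number changes between the methyl and octyl esters, and a butyl or a hexyl ester would show whether the loss comes gradually or suddenly. They also leave open what a carboxylic acid in place of the ester would do on the same core.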